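A few compounds are considered here, and "the series" means these few. Any claim that something is new, unique, unknown or untested is made for them only; others in the source may bear on it.

Measured so far:
compound 1 `C=CCNC(=O)/C(C)=C(\C)c1ccc(Br)cc1`: 33.7 mg/kg
compound 2 `C/C(C(=O)NC1CC1)=C(/C)c1ccc(Br)cc1`: 8.2 mg/kg
compound 3 `C#CCNC(=O)/C(C)=C(\C)c1ccc(F)cc1`: 22.8 mg/kg

In a functional assay on the whole organism (strain Icem-CET (SPF Caw)) for inhibition, with Mus musculus as the target, with a stated time of 30 min (on this read-out higher numbers stand for an effect only at larger amounts of compound and lower numbers for an effect already at smaller amounts), compound 1 stands highest of the three numbers. Compound 3 gives 22.8 mg/kg, which lies within the scatter of compound 1. Within the data shown here, the only step beyond the scatter is a 4.1-fold lower number from compound 1 to compound 2 (0.61 log units; beyond the scatter), a change at the amide nitrogen. Compound 4 `C=CCNC(=O)/C(C)=C(\C)c1ccccc1` differs from compound 1 by hydrogen in place of bromo on an aromatic carbon. Among the measured compounds shown here, no measured step alters the aromatic substituent on its own; compound 3 differs from compound 1 at both the ring and the nitrogen, so its value cannot separate the two changes. With nothing that bears directly on this change, compound 4 is expected to move only within the scatter, a 1.0-fold higher number from compound 1 to compound 4 (0.02 log units; within the scatter). Compound 4 is therefore estimated at 35 mg/kg, between 15 mg/kg and 80 mg/kg.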

Compound 4, dose for half-maximal effect: 67 mg/kg
Estimate against measurement, compound 4: 1.9-fold (0.28 log units) below; low and high end bracket the measured number.
By their numbers in this assay, from the lowest: compound 2; then compounds 3, 1 and 4 (each within the scatter of the next, the first and the last beyond it).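

Hydrogen in place of bromo is the first change here made at the ring alone, and in this assay it gives a 2.0-fold higher number from compound 1 to compound 4 (0.30 log units; within the scatter). Losing the bromo at this place, para to a large group, therefore leaves the number within the usual scatter, although the step sits at the edge of it. Nothing measured on these compounds offers an explanation for this step.

Still open, from the compounds shown here alone, is whether a methoxy or an amine at this place would shift the number further. Also open, going by these compounds, is whether the same change would give a similar step on the cyclopropyl amide of compound 2.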